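The source may hold more compounds than are shown below. What is called first, only, known or untested is meant among the compounds shown, and "the series" means these compounds.

Working notes on the series, read in an ADME assay on HEK293 cells (Homo sapiens) for cytotoxicity, read by resazurin assay, with a stated time of 72 h; a higher number here means that more compound is tolerated, a lower number that less compound is tolerated. Compound 1 `CCc1cccc(CNC(=O)c2nc3ccc(F)c(OCCc4ccc(C(=O)O)cc4)c3c(=O)[nH]2)c1` gives > 20000 nM, which is a limit. Compound 2 `CCc1ccccc1CNC(=O)c1nc2ccc(F)c(OCCc3ccc(C(=O)O)cc3)c2c(=O)[nH]1` gives > 20000 nM, also a limit. Compound 3 `CCc1cccc(C(C)NC(=O)c2nc3ccc(F)c(OCCc4ccc(C(=O)O)cc4)c3c(=O)[nH]2)c1` gives > 20000 nM, again a limit and not a number, so its place in the series cannot be ranked. The same holds across the series: the limit of > 20000 nM in this assay, at which 3 of the 3 values shown sit.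

The next compound is compound 4 `CCc1cccc(CN(C)C(=O)c2nc3ccc(F)c(OCCc4ccc(C(=O)O)cc4)c3c(=O)[nH]2)c1`. The change is (3-ethylbenzyl)(methyl)amino in place of (1-(3-ethylphenyl)ethyl)amino on a carbonyl carbon. The two have the same atoms, joined differently: (3-ethylbenzyl)(methyl)amino stands in place of (1-(3-ethylphenyl)ethyl)amino on a carbonyl carbon.

For the measured compounds named here, two measured steps bear on this change. Going by the values given here, the first is a step that the two limits leave unreadable from compound 1 to compound 3, where methyl replaces hydrogen on a saturated chain carbon bound to an amide-type nitrogen and an aromatic carbon. The second is a step that the two limits leave unreadable from compound 2 to compound 3, where 1-(3-ethylphenyl)ethyl replaces 2-ethylbenzyl on an amide-type nitrogen. Neither has a readable size, so neither gives a direction in this assay.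

The expectation rests on compound 3, whose limit is > 20000 nM, and no step beyond the scatter is expected. The expected change is a step that the limit leaves unreadable from compound 3 to compound 4. A further report as a limit is the likely outcome. For compound 4 the estimated value is 30000 nM, with an expected range of 15000 nM to 60000 nM.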

Compound 4, half-maximal cytotoxic concentration: > 20000 nM
Compound 4 gave a limit, no number; the forecaster's own chance of this, stated with the estimate: 85%; the middle value does not contradict the limit.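

In this assay, for the compounds shown here, compound 4 gives > 20000 nM, a limit and not a number, so no step among compound 1, compound 2, compound 3 and compound 4 can be read. The compounds shown leave open how far any of these changes shifts the tolerated concentration, since all of them stand at one limit: the limit of > 20000 nM in this assay, at which 4 of the 4 values shown sit.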